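The source may hold more compounds than are shown below. What is called first, only, known or untested is meant among the compounds shown, and "the series" means these compounds.

Compound 1 `COc1ncc(NC(=O)[C@H](C)[C@H]2CC[C@@H](c3ccnc4ccc(F)cc43)CC2)cn1`, compound 2 `C[C@@H](c1nc2ccc(Cl)cc2[nH]1)[C@H]1CC[C@@H](c2ccnc3ccc(F)cc32)CC1` and compound 3 `C[C@@H](NS(=O)(=O)c1ccc(Cl)cc1)[C@H]1CC[C@@H](c2ccnc3ccc(F)cc32)CC1` share one core and differ only in the group carried by the short side chain. In an assay on blood for inhibition of Indoleamine 2,3-dioxygenase 1 (Homo sapiens), read by mass spectrometry, with stated times of 4 h and 18 h (on this read-out higher numbers stand for weaker inhibition and lower numbers for stronger inhibition), compound 1 gives 80 nM, compound 2 gives 28 nM, and compound 3 gives 484 nM. Compound 3 stands highest of the three numbers, so it is the weakest inhibitor of this small set, and its gaps to compound 1 and to compound 2 both lie beyond the usual scatter of repeated measurements.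

Compound 4 `C[C@@H](NC(=O)c1cccc(Cl)c1)[C@H]1CC[C@@H](c2ccnc3ccc(F)cc32)CC1` arises from compound 3 by a single change: (3-chlorophenyl)carbonyl in place of (4-chlorophenyl)sulfonyl on an amine nitrogen. The amine nitrogen now carries a carbonyl instead of a sulfonyl, so compound 4 is an amide, as compound 1 is. An amide is expected to do better here because compound 1 gives 80 nM in this assay while the sulfonamide compound 3 gives 484 nM. The expected step of a 4.0-fold lower number from compound 3 to compound 4 (0.61 log units; beyond the scatter) points toward stronger inhibition and beyond the scatter. Compound 4 is therefore estimated at 120 nM, within a range from 40 nM to 400 nM.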

Compound 4, half-maximal inhibitory concentration: 97 nM
Beside the measured number, compound 4's estimate is 1.2-fold (0.09 log units) above it, within the range that was stated.
By their numbers in this assay, from the lowest: compound 2; then compounds 1 and 4 (each within the scatter of the next); then compound 3.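

On the amine nitrogen, the attached group clearly matters: in this assay putting (3-chlorophenyl)carbonyl in place of (4-chlorophenyl)sulfonyl gives a 5.0-fold lower number from compound 3 to compound 4 (0.70 log units; beyond the scatter) and so moves the result toward stronger inhibition. This single swap alters two things at once, the sulfonyl becoming a carbonyl and the chlorine sitting at a different numbered place on the phenyl ring, so the step belongs to both together and cannot be divided between them. Nothing available here explains why the number falls.

A (4-chlorophenyl)carbonyl or a (3-chlorophenyl)sulfonyl group on the same nitrogen would show how much each of the two alterations contributes. Also open, from the compounds shown here alone, is how an unsubstituted phenylcarbonyl or a small acetyl group would compare there, which would test whether the chlorophenyl ring is needed at all.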